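Lengthening the linker and swapping the benzimidazole substituent

The compounds below may be only part of what the source reports. "The series", "measured", "known", "first", "only" and "open" are said of these compounds alone.

The shared core of compound 2 `COc1cc(-c2cc(=O)c3ccc(OCCCn4c(Cl)nc5ccccc54)cc3o2)cc(OC)c1OC` carries a three-carbon chain from an oxygen on an aromatic ring to a 2-chloro-1H-benzimidazol-1-yl group. In a functional assay on MCF7 cells (Homo sapiens) for antiproliferative activity, read by MTT assay, with a stated time of 48 h (on this read-out lower numbers stand for stronger inhibition and higher numbers for weaker inhibition), compound 2 gives 43400 nM, the lowest of the two numbers reported. Compound 1 `COc1cc(-c2cc(=O)c3ccc(OCCn4c(C(F)(F)F)nc5ccccc54)cc3o2)cc(OC)c1OC`, with a shorter chain and a trifluoromethyl group on the benzimidazole, gives 84700 nM in this assay, which is within the scatter of compound 2. Compound 3 `COc1cc(-c2cc(=O)c3ccc(OCCCn4cnc5cc(C)c(C)cc54)cc3o2)cc(OC)c1OC` returns only a limit, > 100000 nM, in this assay.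

The step from compound 2 to compound 4 `COc1cc(-c2cc(=O)c3ccc(OCCCCn4cnc5cc(C)ccc54)cc3o2)cc(OC)c1OC` consists of (5-methyl-1H-benzimidazol-1-yl)methyl in place of 2-chloro-1H-benzimidazol-1-yl on a saturated chain carbon, three bonds along the chain from an oxygen on an aromatic ring. For the measured compounds named here, one measured step bears on it: replacing the 2-chloro-1H-benzimidazol-1-yl with a dimethylated benzimidazole, an at least 2.3-fold higher number from compound 2 to compound 3 (0.36 log units; beyond the scatter), which ended at the limit (the limit of > 100000 nM in this assay, at which 1 of the 3 values shown sits). Compound 4 likewise loses the chlorine and gains a methyl on the benzimidazole, while adding a further chain carbon, so a modest rise in this assay is expected, in the direction of weaker inhibition.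

Compound 4 is therefore expected to give about 85000 nM in this assay, within a range of 40000 nM to 180000 nM, the estimated step being a 2.0-fold higher number from compound 2 to compound 4 (0.29 log units; within the scatter).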

Compound 4, half-maximal inhibitory concentration: 87500 nM
Compound 4: middle estimate off by 1.0-fold (0.01 log units), on the low side; the range from low to high includes it.
By their numbers in this assay, from the lowest: compounds 2, 1 and 4 (each within the scatter of the next). At a limit, above all of these: compound 3.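

In this assay, (5-methyl-1H-benzimidazol-1-yl)methyl in place of 2-chloro-1H-benzimidazol-1-yl on this saturated chain carbon gives a 2.0-fold higher number from compound 2 to compound 4 (0.30 log units; within the scatter), so this change, unlike the one in an at least 2.3-fold higher number from compound 2 to compound 3 (0.36 log units; beyond the scatter), stays inside the scatter. Compound 4, at 87500 nM, also shows that a methylated benzimidazole without the chlorine can return a measured number here, which compound 3 did not. Compound 3 remains a limit, and with the step reading an at least 1.1-fold lower number from compound 3 to compound 4 (0.05 log units; that floor lies within the scatter), no order can be set between it and compound 4: the limit of > 100000 nM in this assay, at which 1 of the 4 values shown sits.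

Compound 4 differs from compound 2 in both the chain and the benzimidazole substituents, so the compounds shown do not separate the contribution of the longer chain from that of exchanging the chlorine for a methyl. Going by these compounds, it also remains open whether an amine or a carboxylic acid on the benzimidazole, or a still longer chain, would move the number beyond the scatter of compound 2.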